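Lengthening a side chain: from ethyl to propyl

This account rests on a few compounds, and the source may have more. Where it says the series, first, only, none or still open, it means among the compounds named here.

Among the compounds with values here, compound 3 `CCNC(=O)Nc1ccc(S(=O)(=O)Oc2ccccc2CC)cc1` gives 3400 nM in a functional assay on MCF7 cells (Homo sapiens) for cytotoxicity, read by sulforhodamine B assay, with a stated time of 48 h (on this read-out higher numbers stand for weaker inhibition and lower numbers for stronger inhibition), the lowest of the three numbers measured so far. Compound 2 `CCNC(=O)Nc1ccc(S(=O)(=O)Oc2ccccc2C)cc1` gives 4500 nM, and compound 1 `CCCc1ccccc1OS(=O)(=O)c1ccc(NC(=O)NCCCCl)cc1` gives 15000 nM. Compound 4 `CCCc1ccccc1OS(=O)(=O)c1ccc(NC(=O)NCC)cc1` differs from compound 3 by methyl in place of hydrogen on a saturated chain carbon, two bonds along the chain from an aromatic carbon. Within the data shown here, the only measured step of this kind is a 1.3-fold lower number from compound 2 to compound 3 (0.12 log units; within the scatter), which lies within the scatter. A further lengthening of the same chain is therefore expected to change the number little; the step of a 1.1-fold lower number from compound 3 to compound 4 (0.05 log units; within the scatter) is an estimate that stays inside the scatter. Compound 4 is expected to give about 3000 nM, within a range from 1500 nM to 6500 nM.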

Compound 4, half-maximal inhibitory concentration: 1300 nM
Compound 4: the middle estimate sits 2.3-fold (0.36 log units) above what was measured; the whole stated range lies above it.
By their numbers in this assay, from the lowest: compound 4; then compounds 3 and 2 (each within the scatter of the next); then compound 1.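

On this chain, going from ethyl to propyl gives a 2.6-fold lower number from compound 3 to compound 4 (0.42 log units; beyond the scatter) in this assay, so lengthening now moves the number beyond the scatter, which a 1.3-fold lower number from compound 2 to compound 3 (0.12 log units; within the scatter) did not do. Measured across the whole series of chains, methyl to propyl gives a 3.5-fold lower number from compound 2 to compound 4 (0.54 log units; beyond the scatter). With propyl kept, the other end of the molecule also matters: hydrogen in place of chloromethyl on the saturated chain carbon, two bonds along the chain from the amide-type nitrogen, gives a 12-fold lower number from compound 1 to compound 4 (1.06 log units; beyond the scatter). Going by these compounds, whether a longer chain such as butyl, or a chain ending in an amine, would lower the number further stays open. Nothing shown gives a reason for these steps.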